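Removing the sulfonyl substituent from the pyridyl alkyne

The compounds below may be only part of what the source reports. "The series", "measured", "known", "first", "only" and "open" are said of these compounds alone.

Measured compounds and values:
compound 1 `CN(C)S(=O)(=O)c1cncc(C#Cc2cc(Cl)ccc2OCC(=O)O)c1` gives 37 nM
compound 2 `CCCS(=O)(=O)c1ccc(C)c(C#Cc2cc(Cl)ccc2OC(C)C(=O)O)c1` gives 1.2 nM
compound 3 `Cc1ccc(S(=O)(=O)N(C)CCCN(C)C)cc1C#Cc1cc(Cl)ccc1OCC(=O)O` gives 287 nM

In an assay on CHO cells for displacement of a labelled ligand from prostaglandin D2 receptor 2 (Homo sapiens), read by scintillation counting (on this read-out higher numbers stand for weaker inhibition and lower numbers for stronger inhibition), compound 1 stands second highest of the three numbers. The nearest number is that of compound 3, which is higher than that of compound 1 and beyond the scatter. The furthest is that of compound 2, which is lower than that of compound 1 and also beyond the scatter. No two of the measured compounds differ in one place only, so no single change has a measured step attached to it.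

Compound 4 `O=C(O)COc1ccc(Cl)cc1C#Cc1cccnc1` is not yet measured. Against compound 1 the change is hydrogen in place of dimethylsulfamoyl on an aromatic carbon. Within the data shown here, all three measured compounds carry a sulfonyl substituent on the ring that bears the alkyne; none shows what happens when that substituent is absent, so the step has no measured counterpart in this set. The dimethylsulfamoyl is a sizeable part of compound 1, and its loss is expected to weaken binding: the step from compound 1 to compound 4 in this assay is expected to be a 14-fold higher number from compound 1 to compound 4 (1.13 log units; beyond the scatter), beyond the scatter and toward a higher number. Compound 4 is therefore estimated at 500 nM, within a range of 100 nM to 3000 nM.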

Compound 4, inhibition constant: 117 nM
Compound 4: the middle estimate sits 4.3-fold (0.63 log units) above what was measured, and the stated range covers the measured number.
By their numbers in this assay, from the lowest: compound 2; then compound 1; then compound 4; then compound 3.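

In this assay, the dimethylsulfamoyl on this aromatic carbon, two atoms from the ring nitrogen, proves not to be essential for a measurable value: hydrogen in its place gives a 3.2-fold higher number from compound 1 to compound 4 (0.50 log units; beyond the scatter), a modest step though beyond the scatter. Among these compounds, this is the only one-place step in the set, and compound 4, at 117 nM, is the only compound with no sulfonyl substituent on the ring bearing the alkyne, so the six heavy atoms of the dimethylsulfamoyl account for only this modest difference on the core of compound 1. Nothing available explains the size of this step.

On these data alone, it remains open whether another group at this place, such as a nitrile, a methylsulfonyl, a carboxamide or an amine, would match compound 1, give a lower number or do no better than hydrogen. As far as these compounds go, it is also open whether removing the sulfonyl substituent would give a step of similar size on the cores of compound 2 and compound 3, neither of which has a hydrogen counterpart in this set.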